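The compounds below may be only part of what the source reports. "The series", "measured", "known", "first", "only" and "open" are said of these compounds alone.

The set holds three measured compounds and one still to be measured, all in an ADME assay on L929 cells (Mus musculus) for cytotoxicity, read by resazurin assay, with a stated time of 72 h; a higher number here means a weaker inhibitor, a lower number a stronger inhibitor. Compound 1 `OB1OCc2ccc(-n3cc(Sc4ccc(F)cc4)c4ccccc43)cc21` gives > 10 ug/mL, which is a limit of the assay and not a number. Compound 2 `CCNC(=O)c1cccn1-c1ccc2c(c1)B(O)OC2` gives > 10 ug/mL, again a limit. Compound 3 `O=C(c1cccc(Cl)c1)c1ccn(-c2ccc3c(c2)B(O)OC3)c1` gives > 10 ug/mL, also a limit, so compound 3 stands where the whole set stands, at the limit of > 10 ug/mL in this assay, at which 3 of the 3 values shown sit. Compound 4 `NCc1ccc(C(=O)c2ccn(-c3ccc4c(c3)B(O)OC4)c2)cc1` differs from compound 3 by 4-(aminomethyl)phenyl in place of 3-chlorophenyl on a carbonyl carbon. Because every measured value rests at the limit of > 10 ug/mL in this assay, at which 3 of the 3 values shown sit, the step is expected to be a step that the limit leaves unreadable from compound 3 to compound 4, nothing beyond the usual scatter in this assay. Compound 4 is therefore estimated at 30 ug/mL, with a range from 10 ug/mL to 100 ug/mL, and most likely reported once more only as a limit.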

Compound 4, half-maximal inhibitory concentration: > 10 ug/mL
Compound 4: a limit, no number; the forecaster's own chance of this, stated with the estimate: 85%; the middle value lies beyond the limit too.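

Within the data shown here, compound 3 and compound 4 both rest at a limit in this assay, so no step between them can be read. The compounds shown leave open what actual value any of them would reach in this assay.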